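Carbonate ester variation on a triazolopyrimidine series

The source may hold more compounds than are shown below. What is called first, only, known or untested is meant among the compounds shown, and "the series" means these compounds.

The series shares one core. Compound 1 `CCCSc1nc(N[C@@H]2C[C@H]2c2ccc(F)c(F)c2)c2nnn([C@@H]3C[C@H](OC(C)=O)[C@@H](O)[C@H]3O)c2n1` has no result in a functional assay on the whole organism (strain Sprague-Dawley) for inhibition, with Rattus norvegicus as the target, with a stated time of 0.5 h, at a dose of 5 mg/kg by the oral route; a higher number here means more inhibition at the dose given (going by the name of the read-out), a lower number less inhibition: for compound 1 the entry reads "not determined" (no result reported). Going by the values given here, compound 2 `CCCSc1nc(N[C@@H]2C[C@H]2c2ccc(F)c(F)c2)c2nnn([C@@H]3C[C@H](OC(=O)OCC)[C@@H](O)[C@H]3O)c2n1` is the only member of this set with a number: in this assay compound 2 gives 42.6%. Among the compounds with values here, compound 3 `CCCSc1nc(N[C@@H]2C[C@H]2c2ccc(F)c(F)c2)c2nnn([C@@H]3C[C@H](OCCOC(=O)CCC)[C@@H](O)[C@H]3O)c2n1` is reported in this assay as "not active" (no number reported), with no figure given, so compound 2 stands alone as the one measured value. Compound 4 `CCCSc1nc(N[C@@H]2C[C@H]2c2ccc(F)c(F)c2)c2nnn([C@@H]3C[C@H](OC(=O)OCC(C)C)[C@@H](O)[C@H]3O)c2n1` differs from compound 2 by isopropyl in place of methyl on a saturated chain carbon bound to an oxygen next to a carbonyl group, ethoxycarbonyl becoming isobutoxycarbonyl. Within the data shown here, no step between measured compounds exists to calibrate this change, so the step from compound 2 to compound 4 is expected to stay within the scatter, at a number 2.6 percentage points lower from compound 2 to compound 4 (within the scatter). Compound 4 is therefore estimated at 40%, between 15% and 65%.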

Compound 4, a percentage reported as inhibition, in the whole organism at one dose (the size of the read-out at that dose, not a potency): 13.2%
Compound 4: middle estimate off by 26.8 percentage points, on the high side; measured number outside the range, below it.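

In this assay, isopropyl in place of methyl on a saturated chain carbon bound to an oxygen next to a carbonyl group gives a number 29.4 percentage points lower from compound 2 to compound 4 (beyond the scatter). This first readable step shows that the read-out at this position responds to the chain, so ethoxycarbonyl and isobutoxycarbonyl are not interchangeable here. Nothing available explains the drop. Steps to compound 1 and compound 3 cannot be read, as neither entry is a number. Open too, going by these compounds, is what a methoxycarbonyl group or an amine-bearing chain would give at this position.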